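Methyl to hydrogen on the ether oxygen of compound 1

The source may hold more compounds than are shown below. What is called first, only, known or untested is meant among the compounds shown, and "the series" means these compounds.

The account follows two compounds built on the same core, the first of them compound 1 `COCCO[C@H](CC=C(C)C)C1=CC(=O)c2c(O)ccc(O)c2C1=O`. Going by the values given here, in a functional assay on HeLa cells (Homo sapiens) for cytotoxicity, read by MTT assay (on this read-out lower numbers stand for stronger inhibition and higher numbers for weaker inhibition), compound 1 gives 62400 nM, and this is the only plain number among the measured results. The second measured compound is compound 2 `CCCCCCC(C)(O)CC(=O)O[C@H](CC=C(C)C)C1=CC(=O)c2c(O)ccc(O)c2C1=O`. In this assay compound 2 gives only a limit, > 100000 nM, so no number is known for it; this is the situation described by the limit of > 100000 nM in this assay, at which 1 of the 2 values shown sits. Among the compounds with values here, no step between measured compounds that differ in a single place is available, so nothing measured says how much a small change at the ether oxygen moves the read-out.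

The unmeasured compound is compound 3 `CC(C)=CC[C@@H](OCCO)C1=CC(=O)c2c(O)ccc(O)c2C1=O`. It differs from compound 1 by hydrogen in place of methyl on an oxygen on a saturated carbon. Since compound 1 itself stands at a high concentration in this assay, compound 3 is expected to stay close to it, and the step of a 1.1-fold lower number from compound 1 to compound 3 (0.05 log units; within the scatter) is estimated to lie within the usual scatter rather than beyond it. Compound 3 is therefore estimated at 55000 nM, with a range from 20000 nM to 150000 nM.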

Compound 3, half-maximal inhibitory concentration: 18600 nM
For compound 3 the middle estimate is 3.0-fold (0.47 log units) above the measured one; the whole stated range lies above it.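

Going by these compounds alone, the first step between compounds that differ in a single place now stands in this assay as a 3.4-fold lower number from compound 1 to compound 3 (0.53 log units; beyond the scatter) and it comes from hydrogen in place of methyl on an oxygen on a saturated carbon. This shows that the read-out responds to the end of this side chain: going from 2-methoxyethyl to 2-hydroxyethyl removes only one heavy atom, yet the step lies beyond the scatter, though it is modest and compound 3 still gives 18600 nM in this cytotoxicity read-out. Nothing given here bears on why the hydroxy form gives the lower number.

With a single step, the compounds shown leave open whether the gain belongs to the free hydroxy itself or would also appear with another group at the end of the chain, such as an amine, a carboxylic acid or a longer chain like 3-hydroxypropyl. They also leave open whether the same exchange of methyl for hydrogen would move the number in the same direction on a side chain other than this one, or on any core other than the shared core.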